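Shortening the ester-bearing chain on the ring amine

The source may report more compounds than this note shows. Statements on the series, on what has been measured and on what is new or still open speak of the compounds shown alone.

In a functional assay (strain AB) with Danio rerio as the target, read by microscopy, with a stated time of 1 h (on this read-out higher numbers stand for an effect only at larger amounts of compound and lower numbers for an effect already at smaller amounts), compound 3 `CC(C)(C)OC(=O)CCCCCN1CCc2c(sc(NC(=O)Nc3ccc(Cl)cc3)c2C(N)=O)C1` gives 620 nM, the lowest of the three numbers seen so far. Compound 1 `CC(C)(C)CN1CCc2c(sc(NC(=O)Nc3ccc(Cl)cc3)c2C(N)=O)C1` gives 5560 nM in this assay, and compound 2 `NC(=O)c1c(NC(=O)Nc2ccc(Cl)cc2)sc2c1CCN(CC1CCC1)C2` gives 1360 nM. The measured steps all involve the group on the ring amine: a 9.0-fold lower number from compound 1 to compound 3 (0.95 log units; beyond the scatter), a 2.2-fold lower number from compound 2 to compound 3 (0.34 log units; beyond the scatter) and a 4.1-fold lower number from compound 1 to compound 2 (0.61 log units; beyond the scatter), so each move toward a larger group at this position lowered the number beyond the scatter.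

Compound 4 `CC(C)(C)OC(=O)CCN1CCc2c(sc(NC(=O)Nc3ccc(Cl)cc3)c2C(N)=O)C1` differs from compound 3 by tert-butoxycarbonyl in place of 3-(tert-butoxycarbonyl)propyl on a saturated chain carbon, two bonds along the chain from an amine nitrogen in a ring. Among the compounds with values here, none of the measured steps tests this exact change, but the step of a 2.2-fold lower number from compound 2 to compound 3 (0.34 log units; beyond the scatter) and the step of a 9.0-fold lower number from compound 1 to compound 3 (0.95 log units; beyond the scatter) both point the same way: smaller groups on the ring amine went with higher numbers. A modest rise is therefore expected for compound 4 in this assay, with a step of a 2.4-fold higher number from compound 3 to compound 4 (0.38 log units; beyond the scatter). Compound 4 is estimated at 1500 nM, within a range of 500 nM to 5000 nM.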

Compound 4, half-maximal effective concentration: 1100 nM
For compound 4 the middle estimate is 1.4-fold (0.13 log units) above the measured one; measured number inside the range.
By their numbers in this assay, from the lowest: compounds 3, 4 and 2 (each within the scatter of the next, the first and the last beyond it); then compound 1.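

In this assay, the shorter ester-bearing chain gives a 1.8-fold higher number from compound 3 to compound 4 (0.25 log units; within the scatter), so over the span from 4-(tert-butoxycarbonyl)butyl to (tert-butoxycarbonyl)methyl, chain length is not resolved from the scatter at this position. The short ester chain and cyclobutyl cannot be told apart either, at a 1.2-fold lower number from compound 2 to compound 4 (0.09 log units; within the scatter), while replacing tert-butyl on that carbon still gives a 5.1-fold lower number from compound 1 to compound 4 (0.70 log units; beyond the scatter), so only compound 1 remains clearly apart from the other three. No evidence is available that bears on these differences.

The compounds shown leave open whether the ester itself matters, since none carries a carboxylic acid, an amide or an unbranched alkyl chain in its place. They also do not show what a chain longer than 4-(tert-butoxycarbonyl)butyl would give.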